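Benzyloxy in Place of the Thiazolyl Amide

The source may report more compounds than this note shows. Statements on the series, on what has been measured and on what is new or still open speak of the compounds shown alone.

Compound 1 `Cc1nn(-c2ncnc3nc[nH]c23)c2c1C(C(=O)N(C)c1nccs1)CC(=O)N2`: 3300 nM in a functional assay on HEK293 cells for agonist activity at G-protein coupled receptor 39 (Homo sapiens), read by scintillation proximity assay and inositol phosphate accumulation, with a stated time of 75 min; on this read-out higher numbers stand for an effect only at larger amounts of compound and lower numbers for an effect already at smaller amounts
Compound 2 `Cc1nn(-c2ncnc3nc[nH]c23)c2c1C(C(=O)NCc1ccc(F)cc1)CC(=O)N2`: 1220 nM in this assay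
Compound 3 `Cc1cc(C)nc(-n2nc(C)c3c2NC(=O)CC3c2ccc(COc3cccc(Cl)c3)cc2)n1`: 3000 nM in this assay

On these numbers compound 1 and compound 3 lie within the usual scatter of each other, and only compound 2 stands apart from compound 1. Compound 4 `Cc1nn(-c2ncnc3nc[nH]c23)c2c1C(OCc1ccccc1C#N)CC(=O)N2` arises from compound 1 by the change ((2-cyanobenzyl)oxy in place of methyl(1,3-thiazol-2-yl)carbamoyl on a saturated ring carbon). Going by the values given here, the one measured step at this position is a 2.7-fold lower number from compound 1 to compound 2 (0.43 log units; beyond the scatter), where (4-fluorobenzyl)amino replaced methyl(1,3-thiazol-2-yl)amino. Among the compounds with values here, compound 4 goes further, since (2-cyanobenzyl)oxy replaces the whole methyl(1,3-thiazol-2-yl)carbamoyl, so no measured pair covers it directly; a modest gain in this assay is expected on the strength of that single step. For compound 4 the estimated step is a 1.7-fold lower number from compound 1 to compound 4 (0.22 log units; within the scatter). Compound 4 is therefore expected to give about 2000 nM, within 600 nM to 7000 nM.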

Compound 4, half-maximal effective concentration: 127 nM
Compound 4: middle estimate off by 16-fold (1.20 log units), on the high side, and the stated range ends above it.
By their numbers in this assay, from the lowest: compound 4; then compound 2; then compounds 3 and 1 (each within the scatter of the next).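

In this assay, putting (2-cyanobenzyl)oxy on the saturated ring carbon gives a 26-fold lower number from compound 1 to compound 4 (1.41 log units; beyond the scatter), so the methyl(1,3-thiazol-2-yl)carbamoyl is not needed at this position for an effect at small amounts of compound. This step is much larger than a 2.7-fold lower number from compound 1 to compound 2 (0.43 log units; beyond the scatter), which kept the carbonyl carbon in place. Nothing available explains the size of the step. The compounds shown leave open whether the gain belongs to the ether oxygen or to the nitrile, which a plain benzyloxy or a (2-cyanobenzyl)amino group on this carbon could separate.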